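The source may report more compounds than this note shows. Statements on the series, on what has been measured and on what is new or still open speak of the compounds shown alone.

Working notes on the series. In a functional assay on CCRF-CEM cells for inhibition of C-X-C chemokine receptor type 4 (Homo sapiens), read by calcium flux (a higher number here means a weaker inhibitor, a lower number a stronger inhibitor), compound 1 `CN(/C(=N/C1CCCCC1)SCC1=CSC2=NCCN12)C1CCCCC1` gives 931 nM, and compound 2 `C1=C(CS/C(=N\C2CCCC2)NC2CCCC2)N2CCN=C2S1` gives 493 nM. Compound 3 `C1=C(CS/C(=N\C2CCCCC2)NC2CCCCCCC2)N2CCN=C2S1` gives 8 nM in this assay, the lowest of the three numbers, with the gaps to compound 2 and to compound 1 both beyond the scatter. Within the data shown here, the one single-point step recorded, a 120-fold lower number from compound 1 to compound 3 (2.07 log units; beyond the scatter), is large. Compound 4 `C1=C(CS/C(=N\C2CCCCC2)Nc2ccccc2)N2CCN=C2S1` differs from compound 3 in one place: phenyl in place of cyclooctyl on an amine nitrogen. Among the measured compounds shown here, no measured step swaps the ring on the amine nitrogen alone, so the size of the effect in this assay is open; that recorded step shows only that this position moves the number strongly. A higher number is therefore expected for compound 4, a 10-fold higher number from compound 3 to compound 4 (1.00 log units; beyond the scatter), estimated at 80 nM with a range from 15 nM to 400 nM.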

Compound 4, half-maximal inhibitory concentration: 5280 nM
For compound 4 the middle estimate is 66-fold (1.82 log units) below the measured one, outside the stated range (above it).
By their numbers in this assay, from the lowest: compound 3; then compounds 2 and 1 (each within the scatter of the next); then compound 4.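

Replacing cyclooctyl with phenyl on the amine nitrogen, with nothing else changed, gives a 660-fold higher number from compound 3 to compound 4 (2.82 log units; beyond the scatter) in this assay, so this one ring alone can move the number strongly upward. Anilino also falls behind cyclohexyl(methyl)amino, at a 5.7-fold higher number from compound 1 to compound 4 (0.75 log units; beyond the scatter), so this position can move the number in either direction from compound 1, not only lower it. Nothing at hand bears on the cause of these shifts.

Phenyl differs from cyclooctyl in both ring size and aromaticity, and these two changes remain unseparated here. Cycloheptyl or benzyl on this amine nitrogen would help to tell them apart.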